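Taking the Bromo off Compound 2

A few compounds are considered here, and "the series" means these few. Any claim that something is new, unique, unknown or untested is made for them only; others in the source may bear on it.

In an ADME assay on cells (Homo sapiens) for antiproliferative activity, read by MTT assay (a lower number here means a stronger inhibitor, a higher number a weaker inhibitor), compound 1 (`O=C(NN=C(c1ccccn1)c1ccccn1)c1cccc(Br)c1`) gives 240 nM as its reading. Compound 2 (`C/C(=N\NC(=O)c1cccc(Br)c1)c1cnccn1`) gives 1150 nM and so holds the higher of the two numbers, which makes it the weaker inhibitor by a gap beyond the usual scatter. Compound 3 (`C/C(=N\NC(=O)c1ccccc1)c1cnccn1`) has no reading yet in this assay and differs from compound 2 by hydrogen in place of bromo on an aromatic carbon. Among the compounds with values here, both measured compounds carry the bromo, so no measured pair shows what losing it does, and any expectation stays loose. A modest move toward a higher number is expected, possibly not beyond the scatter. The estimated change is a 1.6-fold higher number from compound 2 to compound 3 (0.19 log units; within the scatter) and it remains a rough guess. Compound 3 is estimated at 1800 nM (expected range 600 nM to 5000 nM).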

Compound 3, half-maximal inhibitory concentration: 3620 nM
Beside the measured number, compound 3's estimate is 2.0-fold (0.30 log units) below it; the measured number falls inside the stated range.
By their numbers in this assay, from the lowest: compound 1; then compound 2; then compound 3.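

Removing the bromo gives a 3.1-fold higher number from compound 2 to compound 3 (0.50 log units; beyond the scatter) in this assay, and this is the only pair shown that isolates this change. At this place, meta to a large group, hydrogen therefore gives a weaker inhibitor than bromo on this scaffold. This step lies beyond the usual scatter. Nothing measured here gives a reason for the size of this step.

On these data alone, it remains open whether another group at this place, such as chlorine, methoxy or an amine, would match the bromo, or whether a hydrogen there would be any better tolerated in a different setting. As far as these compounds go, compound 1 differs from compound 2 in more than one place, so whether removing its bromo would produce a similar loss also remains unknown.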